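Furan-2-yl in place of phenyl: expected cytotoxicity

A few compounds are considered here, and "the series" means these few. Any claim that something is new, unique, unknown or untested is made for them only; others in the source may bear on it.

Measured so far in an ADME assay on Vero cells (Chlorocebus sabaeus) for cytotoxicity, read by resazurin assay, with a stated time of 3 days; on this read-out higher numbers stand for weaker inhibition and lower numbers for stronger inhibition:
Compound 1, `CN(C)c1cc2[nH]c(C3CCCCC3)nc2cc1NC(=O)c1ccc(OC(F)F)cc1`, gives > 100 ug/mL, which is a limit of the assay.
Compound 2, `CN(C)c1cc2[nH]c(C3CCCCC3)nc2cc1NC(=O)c1ccc(C(C)(C)C)cc1`, gives > 100 ug/mL, likewise a limit.
Compound 3, `CN(C)c1cc2[nH]c(C3CCCCC3)nc2cc1NC(=O)c1ccccc1`, gives > 100 ug/mL, again a limit.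

Compound 3 thus stands at the limit that all three share, as the limit of > 100 ug/mL in this assay, at which 3 of the 3 values shown sit, records; no one of the three is known to differ from another. The steps a step that the two limits leave unreadable from compound 1 to compound 3 and a step that the two limits leave unreadable from compound 2 to compound 3 stay unreadable, as does a step that the two limits leave unreadable from compound 1 to compound 2. Compound 4, `CN(C)c1cc2[nH]c(C3CCCCC3)nc2cc1NC(=O)c1ccco1`, differs from compound 3 by furan-2-yl in place of phenyl on a carbonyl carbon. Among the measured compounds shown here, no measured step touches the carbonyl carbon, so only the shared limit bears on this change. Compound 4 is therefore expected to sit near that limit too, with a step that the limit leaves unreadable from compound 3 to compound 4 expected to be small. The estimate for compound 4 in this assay is 150 ug/mL, within 50 ug/mL to 500 ug/mL.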

Compound 4, half-maximal inhibitory concentration: > 100 ug/mL
Compound 4: no number, only a limit (the forecaster's own chance of this, stated with the estimate: 80%); the middle value does not contradict the limit.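

In this assay no step can be read among compound 1, compound 2, compound 3 and compound 4, since all four share one limit: the limit of > 100 ug/mL in this assay, at which 4 of the 4 values shown sit.

The compounds shown leave open whether any group on the carbonyl carbon would bring cytotoxicity within the measurable range.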